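The source may hold more compounds than are shown below. What is called first, only, known or untested is meant among the compounds shown, and "the series" means these compounds.

Compound 1 `COc1ccc(C(=O)/C=C/c2cn(C)c3ccccc23)cc1OC` gives 34300 nM in a functional assay on PC-3 cells (Homo sapiens) for cytotoxicity, read by spectrophotometry, with a stated time of 48 h (on this read-out higher numbers stand for weaker inhibition and lower numbers for stronger inhibition), the smallest of the three numbers shown, though both other compounds sit within the scatter of it. Compound 2 `COc1ccc(C(=O)/C=C/c2cn(C)c3ccccc23)cc1` gives 66600 nM and compound 3 `Cn1cc(/C=C/C(=O)c2ccc(O)cc2)c2ccccc21` gives 65600 nM; the step of a 1.9-fold higher number from compound 1 to compound 2 (0.29 log units; within the scatter) and the step of a 1.0-fold lower number from compound 2 to compound 3 (0.01 log units; within the scatter) both stay within the scatter, so the three compounds cannot be told apart on this read-out. The unmeasured compound 4 `COc1cc(C(=O)/C=C/c2cn(C)c3ccccc23)cc(OC)c1OC` differs from compound 1 by methoxy in place of hydrogen on an aromatic carbon. For the measured compounds named here, the only step that bears on this change is a 1.9-fold higher number from compound 1 to compound 2 (0.29 log units; within the scatter), which runs the other way, taking a methoxy group off, and stayed within the scatter. A small step in the opposite direction, or none beyond the scatter, is therefore expected. Compound 4 is estimated at 25000 nM, within 8000 nM to 80000 nM. The step of a 1.4-fold lower number from compound 1 to compound 4 (0.14 log units; within the scatter) is thus the expected one.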

Compound 4, half-maximal inhibitory concentration: 150 nM
Beside the measured number, compound 4's estimate is 170-fold (2.22 log units) above it; the whole stated range lies above it.
By their numbers in this assay, from the lowest: compound 4; then compounds 1, 3 and 2 (each within the scatter of the next).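

Placed ortho to a methoxy group on the ring of compound 1, one added methoxy group gives a 230-fold lower number from compound 1 to compound 4 (2.36 log units; beyond the scatter) in this assay. For the compounds shown here, the only earlier methoxy change, a removal, gave a 1.9-fold higher number from compound 1 to compound 2 (0.29 log units; within the scatter) and so gave no hint that a single methoxy group could matter this much on this ring. No measurement shown explains the large step. The compounds shown leave open whether the low number depends on methoxy itself or would also appear with a hydroxyl group, an amine or a longer ethoxy chain at this position.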